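The source may report more compounds than this note shows. Statements on the series, on what has been measured and on what is new or still open speak of the compounds shown alone.

In a functional assay on A549 cells (Homo sapiens) for antiproliferative activity, read by MTT assay, with a stated time of 72 h (a higher number here means a weaker inhibitor, a lower number a stronger inhibitor), compound 1 `Cn1cc(Nc2nn(Cc3ccc(C(=O)NC4CCCCC4)cc3)c(=O)c3ccccc23)cn1` gives 6800 nM, and compound 3 `Cn1cc(-c2nn(Cc3ccc(C(=O)N4CCCCC4)cc3)c(=O)c3ccccc23)cn1` gives 67400 nM. Compound 2 `Cc1noc(C)c1-c1nn(Cc2ccc(C(=O)NC3CC3)cc2)c(=O)c2ccccc12` sits at the limit of > 100000 nM in this assay, at which 1 of the 3 values shown sits, a boundary of the measurement rather than a number, reported as > 100000 nM. The change leading to compound 4 `Cc1noc(C)c1-c1nn(Cc2ccc(C(=O)NC3CCN(C)CC3)cc2)c(=O)c2ccccc12` is 1-methylpiperidin-4-yl in place of cyclopropyl on an amide-type nitrogen. Going by the values given here, no measured pair on the shared core shows this same exchange, so its effect cannot be read from the numbers gathered so far. Starting from a limit, the expected step is an at least 1.6-fold lower number from compound 2 to compound 4 (0.22 log units; that floor lies within the scatter), leaning toward a stronger inhibitor but only modestly. Compound 4 is therefore estimated at 60000 nM, within a range from 15000 nM to 150000 nM, with a real chance that it also ends on the limit.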

Compound 4, half-maximal inhibitory concentration: > 100000 nM
Compound 4 ended at the assay's limit (the forecaster's own chance of this, stated with the estimate: 40%); middle value at least 1.6-fold (0.22 log units) from the limit.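

Compound 2 and compound 4 both rest on the assay's limit, so no step can be read between them: the limit of > 100000 nM in this assay, at which 2 of the 4 values shown sit.

On these data alone, whether 1-methylpiperidin-4-yl in place of cyclopropyl on an amide-type nitrogen changes the result in this assay stays open.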